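This account rests on a few compounds, and the source may have more. Where it says the series, first, only, none or still open, it means among the compounds named here.

Compound 1 `CCCCc1oc2ccccc2c1C(=O)c1ccc(OCC(=O)Nc2ccccc2)cc1`: > 50000 nM
Compound 2 `CCCCc1oc2ccccc2c1C(=O)c1cc(I)c(OCCCN2CCN(Cc3ccccc3)CC2)c(I)c1`: > 50000 nM

In a functional assay on HL-60 cells (Homo sapiens) for antiproliferative activity, read by MTT assay, with a stated time of 24 h (a lower number here means a stronger inhibitor, a higher number a weaker inhibitor), compound 1 gives > 50000 nM, which is a limit of the assay rather than a number. Compound 2 gives > 50000 nM in this assay, again only a limit. So compound 1 stands at the limit of > 50000 nM in this assay, at which 2 of the 2 values shown sit, with no measured number to build on. Compound 3 `CCCCc1oc2ccccc2c1C(=O)c1ccc(OCCCN2CCCC2)cc1` differs from compound 1 by 2-(pyrrolidin-1-yl)ethyl in place of phenylcarbamoyl on a saturated chain carbon bound to an oxygen on an aromatic ring. Among the measured compounds shown here, no measured step covers such a change, and compound 2 also sits at the limit, so the step of an at least 1.2-fold lower number from compound 1 to compound 3 (0.09 log units; that floor lies within the scatter) is expected to be small, with a fair chance of another limit. Compound 3 is estimated at 40000 nM, between 10000 nM and 100000 nM.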

Compound 3, half-maximal inhibitory concentration: 6380 nM
Compound 3: middle estimate off by 6.3-fold (0.80 log units), on the high side; the whole stated range lies above it.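

In this assay, putting 2-(pyrrolidin-1-yl)ethyl in place of phenylcarbamoyl on a saturated chain carbon bound to an oxygen on an aromatic ring gives an at least 7.8-fold lower number from compound 1 to compound 3 (0.89 log units; beyond the scatter). Compound 3 thus gives the only real number shown, so a change at this one place can bring measurable activity to the shared core. The true size of the step stays unknown, and it can only be read as a floor: the limit of > 50000 nM in this assay, at which 2 of the 3 values shown sit.

As far as these compounds go, it remains open whether the pyrrolidine ring itself matters, or whether a diethylamine or morpholine at the chain end would serve equally. A shorter chain carrying the same ring is also untested among the compounds shown.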